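A Shortened Thioamide Side Chain on the Shared Core

A few compounds are considered here, and "the series" means these few. Any claim that something is new, unique, unknown or untested is made for them only; others in the source may bear on it.

Compound 1 `CC/N=C(\S)CCn1nc(-c2ccccc2)ccc1=O` gives 100 mg/kg in a functional assay on the whole organism (stomach) with Rattus norvegicus as the target; a higher number here means that more compound is needed for the effect, a lower number that less compound is needed. Compound 2 `N=C(S)CCCCCCn1nc(-c2ccccc2)ccc1=O` reaches only the limit of this assay, > 100 mg/kg.

For the measured compounds named here, compound 1 thus stands at the only number given; the other value is a limit. Compound 3 `CC(Cn1nc(-c2ccccc2)ccc1=O)C(=N)S` differs from compound 1 in that it carries a group of 5 heavy atoms (3 carbon, 1 nitrogen, 1 sulfur; no ring) in place of a group of 6 heavy atoms (4 carbon, 1 nitrogen, 1 sulfur; no ring), on a saturated chain carbon bound to an aromatic nitrogen. Going by the values given here, the one measured step that bears on a change in this side chain, a number no lower from compound 1 to compound 2 (the limit leaves the size open), sits at the limit of > 100 mg/kg in this assay, at which 1 of the 2 values shown sits, and gives no size, only that the dose did not fall. From that, no gain beyond the scatter is expected for compound 3 in this assay; the step of a 1.3-fold higher number from compound 1 to compound 3 (0.11 log units; within the scatter) is estimated to stay near compound 1, with a fair chance that only a limit is reported. Compound 3 is expected at 130 mg/kg, within 45 mg/kg to 400 mg/kg.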

Compound 3, dose for half-maximal effect: 28.1 mg/kg
The estimate for compound 3 lay 4.6-fold (0.67 log units) above the measured number, and the stated range ends above it.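

On the saturated chain carbon bound to an aromatic nitrogen, putting the group of 5 heavy atoms in place of the group of 6 heavy atoms gives a 3.6-fold lower number from compound 1 to compound 3 (0.55 log units; beyond the scatter) in this assay. For the compounds shown here, this modest step shows that a change in this side chain can lower the dose needed for the effect, which the earlier compounds did not show. Compound 2 is a limit, so its step gave no size and no such direction: the limit of > 100 mg/kg in this assay, at which 1 of the 3 values shown sits.

Going by these compounds alone, the single step does not tell which part of the exchanged group carries the lower number. As far as these compounds go, whether a primary amide, an amine or a carboxylic acid in place of this group would keep that lower number remains open.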